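Chain-linked aryl groups on a shared purinedione core

This account rests on a few compounds, and the source may have more. Where it says the series, first, only, none or still open, it means among the compounds named here.

Compounds measured in an assay on microsomes for inhibition of Amine oxidase [flavin-containing] B (Homo sapiens), read by fluorescence and spectrophotometry, with a stated time of 20 min; on this read-out lower numbers stand for stronger inhibition and higher numbers for weaker inhibition:
compound 1 `COc1ccc(CCSc2nc3c(c(=O)n(C)c(=O)n3C)n2C)cc1` gives 23 nM
compound 2 `COc1cccc(CCSc2nc3c(c(=O)n(C)c(=O)n3C)n2C)c1` gives 125 nM

Within the data shown here, compound 2 stands highest of the two numbers so far, since a 5.4-fold higher number from compound 1 to compound 2 (0.74 log units; beyond the scatter). Among the measured compounds shown here, the only measured step thus shows that moving the methoxy group around the ring already carries a cost beyond the scatter.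

Compound 3 `Cn1c(=O)c2c(nc(SCCCc3cccc(Cl)c3)n2C)n(C)c1=O` differs from compound 2 by 3-chlorobenzyl in place of 3-methoxyphenyl on a saturated chain carbon, two bonds along the chain from a sulfur. For the measured compounds named here, no measured pair bears on this change directly: the single step from compound 1 to compound 2 concerns only where the methoxy group sits, and nothing measured here tells how a chlorine in place of a methoxy, or a chain one carbon longer, shifts the read-out. The estimate therefore leans on compound 2 alone, with a wide range to allow for either direction. Compound 3 is expected at about 100 nM in this assay, within 25 nM to 400 nM, which would mean a 1.3-fold lower number from compound 2 to compound 3 (0.10 log units; within the scatter), a step not expected to be clearly beyond the scatter.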

Compound 3, half-maximal inhibitory concentration: 62 nM
The estimate for compound 3 lay 1.6-fold (0.21 log units) above the measured number; the measured number falls inside the stated range.
By their numbers in this assay, from the lowest: compound 1; then compounds 3 and 2 (each within the scatter of the next).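

In this assay, putting 3-chlorobenzyl in place of 3-methoxyphenyl on a saturated chain carbon, two bonds along the chain from a sulfur, gives a 2.0-fold lower number from compound 2 to compound 3 (0.30 log units; within the scatter). The entering group carries no hydrogen-bond acceptor, yet the step stays within the scatter, so among these compounds the methoxy oxygen is not shown to be needed at this place, and a chlorine-bearing group serves there about as well as the methoxy-bearing one. The comparison with the 4-methoxyphenyl group reads differently, with a 2.7-fold higher number from compound 1 to compound 3 (0.43 log units; beyond the scatter), so compound 1 keeps the lowest number, its steps to both others lying beyond the scatter, and nothing given here accounts for either step.

The chlorine and the longer chain arrive together in compound 3, so the compounds shown leave their separate shares in the read-out unresolved. Also open, as far as these compounds go, is how a 4-chlorobenzyl or 4-methoxybenzyl group would compare on this chain, and whether an amine or a carboxylic acid on the ring would be accepted at all.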